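From compound 2 to compound 3: one group exchanged

The source may hold more compounds than are shown below. What is called first, only, known or untested is meant among the compounds shown, and "the series" means these compounds.

Compound 1 `O=Cc1ccccc1OCc1ccc2no[n+]([O-])c2c1`: > 100 uM
Compound 2 `N=C(N)N/N=C\c1ccccc1OCc1ccc2no[n+]([O-])c2c1`: 58 uM

In an ADME assay on cells (Erythrocyte, Homo sapiens), read by spectrophotometry and hemolysis, with a stated time of 24 h (a higher number here means a weaker inhibitor, a lower number a stronger inhibitor), compound 1 gives > 100 uM as a limit of the assay, not a number. Among the compounds with values here, compound 2 gives 58 uM as the only actual number so far. Compound 3 `NC(=S)N/N=C\c1ccccc1OCc1ccc2no[n+]([O-])c2c1` differs from compound 2 by one change on an amine nitrogen, counted as a group of 3 heavy atoms (1 carbon, 1 nitrogen, 1 sulfur; no ring) in place of a group of 3 heavy atoms (1 carbon, 2 nitrogen; no ring), on an amine nitrogen in full. Within the data shown here, because of an at least 1.7-fold lower number from compound 1 to compound 2 (0.23 log units; that floor lies within the scatter) alone, the only measured step and one that starts from a limit, no shift beyond the scatter is expected. The expected change is a 1.4-fold higher number from compound 2 to compound 3 (0.14 log units; within the scatter) by this estimate. For compound 3 the estimated value is 80 uM, expected to fall from 35 uM to 180 uM in this assay.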

Compound 3, concentration for 50% inhibition: 189 uM
Beside the measured number, compound 3's estimate is 2.4-fold (0.37 log units) below it, and the stated range ends below it.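

In this assay, within the data shown here, the exchange on the amine nitrogen gives a 3.3-fold higher number from compound 2 to compound 3 (0.51 log units; beyond the scatter), the first step here with a real number at both ends. Groups of equal heavy-atom count, differing in sulfur for nitrogen, are therefore not interchangeable at this place. The step from compound 1 to compound 3 cannot be read, because compound 1 stands at a limit: the limit of > 100 uM in this assay, at which 1 of the 3 values shown sits.

A single pair cannot show whether sulfur itself or the lost nitrogen drives the shift. Where a group with oxygen in place of that sulfur, or a longer chain on this nitrogen, would fall remains open.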